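Methyl to fluoro on a weak antiproliferative compound

A few compounds are considered here, and "the series" means these few. Any claim that something is new, unique, unknown or untested is made for them only; others in the source may bear on it.

Compound 1 `O=C(NNc1ccccc1Cl)c1ccc(NS(=O)(=O)c2cnc(O)nc2O)cc1`: 3340 nM
Compound 2 `Cc1ccccc1NNC(=O)c1cccc(NS(=O)(=O)c2cnc(O)nc2O)c1`: 14200 nM

Both compounds were tested in a functional assay on A549 cells (Homo sapiens) for antiproliferative activity, read by MTT assay, with a stated time of 24 h; on this read-out higher numbers stand for weaker inhibition and lower numbers for stronger inhibition. Going by the values given here, compound 2 has the higher of the two numbers, at 14200 nM, and its only neighbour, compound 1, gives 3340 nM, a gap beyond the scatter. These two compounds differ in more than one place, so their gap cannot be read as the effect of a single change.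

Compound 3 `O=C(NNc1ccccc1F)c1cccc(NS(=O)(=O)c2cnc(O)nc2O)c1` has not yet been measured in this assay. It differs from compound 2 in one place: fluoro in place of methyl on an aromatic carbon. This puts fluoro in place of methyl on an aromatic carbon, ortho to a large group. Among the compounds with values here, no measured pair shows this swap, so the data offer no direct guide to its size. With so little to go on, no step beyond the scatter is expected in this assay, with only a slight lean towards stronger inhibition. The expected change is a 1.4-fold lower number from compound 2 to compound 3 (0.15 log units; within the scatter). The estimate for compound 3 is 10000 nM, with an expected range from 3500 nM to 28000 nM.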

Compound 3, half-maximal inhibitory concentration: 11100 nM
Compound 3: the middle estimate sits 1.1-fold (0.05 log units) below what was measured; the range from low to high includes it.
By their numbers in this assay, from the lowest: compound 1; then compounds 3 and 2 (each within the scatter of the next).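

In this assay, placing fluoro in place of methyl on this aromatic carbon, ortho to a large group, gives a 1.3-fold lower number from compound 2 to compound 3 (0.11 log units; within the scatter). Going by these compounds alone, this is the first direct reading at this position, and it shows that this particular swap leaves the antiproliferative read-out within the scatter, so compound 2 and compound 3 cannot be told apart here and both remain weak in absolute terms. Within the data shown here, no measurement offered here explains this outcome, and the single pair shows only that the position tolerates this one exchange, not how it would respond to other changes.

The compounds shown leave open whether any group at this same place could shift the number beyond the scatter, for instance a bare hydrogen, a methoxy, a trifluoromethyl, an amine or a carboxylic acid. They also leave open whether the same swap would give a similar result on a different core, since a single pair cannot show whether this outcome carries over to other compounds.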